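Dimethyl for dichloro on the aryl ring of compound 2

This account rests on a few compounds, and the source may have more. Where it says the series, first, only, none or still open, it means among the compounds named here.

Measured in an assay on isolated protein for inhibition of ATP-citrate synthase (Rattus norvegicus); a lower number here means a stronger inhibitor, a higher number a weaker inhibitor:
compound 1 `O=C(O)CC(O)(CSCCc1ccc(Cl)cc1Cl)C(=O)O` — 480000 nM
compound 2 `O=C(O)CC(O)(CSCCCCCCc1ccc(Cl)cc1Cl)C(=O)O` — 3300 nM
compound 3 `O=C(O)CC(O)(CSCCCCCCc1c(Cl)cc(Cl)cc1-c1ccccc1)C(=O)O` — 10000 nM

Compound 2 gives the lowest number of the three in this assay; compound 3 stands nearest, a 3.0-fold higher number from compound 2 to compound 3 (0.48 log units; beyond the scatter), and compound 1 stands furthest with a far higher number. Compound 4 `Cc1ccc(CCCCCCSCC(O)(CC(=O)O)C(=O)O)c(C)c1` differs from compound 2 in one place: 2,4-dimethylphenyl in place of 2,4-dichlorophenyl on a saturated chain carbon, six bonds along the chain from a sulfur. Among the compounds with values here, no measured step bears directly on this change. Within the data shown here, the only step measured, from compound 2 to compound 3, concerns a phenyl added to the ring and says nothing about swapping chlorine for methyl; the values of compound 1 and compound 2 differ in chain length only. With nothing closer to lean on, the change is expected to move this assay little, if at all, beyond the scatter: a 1.7-fold higher number from compound 2 to compound 4 (0.22 log units; within the scatter). Compound 4 is therefore estimated at 5500 nM, with a range from 1800 nM to 18000 nM.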

Compound 4, inhibition constant: 160000 nM
Compound 4: the middle estimate sits 29-fold (1.46 log units) below what was measured, outside the stated range (above it).
By their numbers in this assay, from the lowest: compound 2; then compound 3; then compound 4; then compound 1.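

In this assay, the ring group on a saturated chain carbon, six bonds along the chain from a sulfur, proves highly sensitive to this exchange: 2,4-dimethylphenyl in place of 2,4-dichlorophenyl gives a 48-fold higher number from compound 2 to compound 4 (1.69 log units; beyond the scatter), a much larger step than the phenyl addition, a 3.0-fold higher number from compound 2 to compound 3 (0.48 log units; beyond the scatter). The two groups match in heavy-atom count and in hydrogen-bond donors and acceptors, so these counts do not track the step. No available measurement accounts for it.

Open, on these data alone, is whether both chlorines contribute to the step or only one. A ring with one chlorine and one methyl, or with bromine or trifluoromethyl in place of chlorine, would test this.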